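A few compounds are considered here, and "the series" means these few. Any claim that something is new, unique, unknown or untested is made for them only; others in the source may bear on it.

Compound 1, `CC(C)n1cnc2c(Nc3ccccc3)nc(NCOCc3ccc(/C=C/C(=O)Nc4ccccc4N)cc3)nc21`, gives 1.46% in a functional assay on HepG2 cells (Homo sapiens) for antiproliferative activity, read by CCK-8 assay, with a stated time of 72 h, tested at 2 uM; on this read-out higher numbers stand for a stronger effect at the one concentration tested and lower numbers for a weaker effect.
Compound 2, `Cc1ccc(Nc2nc(Cl)nc3c2ncn3Cc2ccc(C(=O)Nc3ccccc3N)cc2)cc1`, gives 76.2% in this assay.
Compound 3, `Nc1ccccc1NC(=O)c1ccc(Cn2cnc3c(Nc4ccccc4)nc(Cl)nc32)cc1`, gives 49.6% in this assay.

Compound 3 stands second highest of the three numbers: compound 2 lies above it, and that gap is shown by a number 26.6 percentage points lower from compound 2 to compound 3 (beyond the scatter), which comes from hydrogen in place of methyl on an aromatic carbon. Within the data shown here, compound 1 lies far below both, but it differs from compound 3 in more than one place, so no single step is drawn between them.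

Compound 4, `Nc1ccccc1NC(=O)c1ccc(Cn2cnc3c(NCc4ccccc4)nc(Cl)nc32)cc1`, is not yet measured. It differs from compound 3 by benzyl in place of phenyl on a nitrogen on an aromatic ring. Among the measured compounds shown here, none of the measured steps touches this part of the shared core, so there is no direct guide to its size or direction. For the measured compounds named here, the one measured step, a number 26.6 percentage points lower from compound 2 to compound 3 (beyond the scatter), shows only that a small change to an outer ring on this core can move the number by a modest amount beyond the scatter. For compound 4 in this assay, a modest step downward is therefore expected, a number 9.6 percentage points lower from compound 3 to compound 4 (within the scatter), though a move in either direction within that size would not be surprising. The estimate for compound 4 is 40%, with a range from 15% to 65%.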

Compound 4, a percentage reported as inhibition, at one concentration (the size of the read-out at that concentration, not a potency): 7.55%
Beside the measured number, compound 4's estimate is 32.5 percentage points above it; the measured number lies below the stated range.
By their numbers in this assay, from the lowest: compounds 1 and 4 (each within the scatter of the next); then compound 3; then compound 2.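

The aromatic ring on this nitrogen turns out to be sensitive to how it is attached: changing anilino to benzylamino, with the ring itself unchanged, gives a number 42.1 percentage points lower from compound 3 to compound 4 (beyond the scatter), a large step where the earlier change on this same ring, a number 26.6 percentage points lower from compound 2 to compound 3 (beyond the scatter), was modest. The comparison with the methyl-bearing compound points the same way, since benzyl in place of 4-methylphenyl gives a number 68.7 percentage points lower from compound 2 to compound 4 (beyond the scatter), so among these three compounds both groups attached directly through the anilino nitrogen keep a clear effect in this assay and the benzyl compound does not. No measurement shown here explains why this change has such a large effect on the read-out.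

On these data alone, it remains open whether the loss grows, holds or reverses with a longer chain such as 2-phenylethyl on this nitrogen, and whether a 4-methylbenzyl group would recover any of the number in the way that the methyl on the phenyl ring goes with the higher value of compound 2. Each of these numbers also comes from a single concentration, so they describe the size of the effect at that concentration and not a potency.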